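A few compounds are considered here, and "the series" means these few. Any claim that something is new, unique, unknown or untested is made for them only; others in the source may bear on it.

Compound 1 `C=CCNC(=O)n1c(-c2ccc(OC)cc2)cc(=O)c2c(OC)cc(OC)cc21` was tested in a functional assay on HepG2 cells (Homo sapiens) for antiproliferative activity, with a stated time of 72 h; on this read-out higher numbers stand for an effect only at larger amounts of compound and lower numbers for an effect already at smaller amounts. In this assay compound 1 gives > 20000 nM, which is a limit of the assay and not a number. Compound 2 `COC(=O)c1cc(=O)c2c(OC)cc(OC)cc2[nH]1` shares the core of compound 1 but carries a different set of groups. In this assay compound 2 gives > 34400 nM, again a limit rather than a number. Compound 1 therefore stands at the limit of > 20000 nM in this assay, at which 1 of the 2 values shown sits, so no order between compound 1 and compound 2 can be read from the values shown. Compound 3 `COc1ccc(-c2cc(=O)c3c(OC)cc(OC)cc3n2S(=O)(=O)c2ccc(Br)s2)cc1` has not yet been measured in this assay. It differs from compound 1 in one place ((5-bromothiophen-2-yl)sulfonyl in place of allylcarbamoyl on an aromatic nitrogen). Within the data shown here, no measured step of this kind exists, so the expected step of a number no higher from compound 1 to compound 3 (the limit leaves the size open) is one of no change beyond the scatter in this assay. Compound 3 is estimated at 20000 nM, within 5000 nM to 60000 nM, most likely again reported only as a limit.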

Compound 3, half-maximal effective concentration: > 48200 nM
Compound 3 ended at the assay's limit; the forecaster's own chance of this, stated with the estimate: 65%; middle value at least 2.4-fold (0.38 log units) from the limit.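

Compound 1 and compound 3 both end at limits of this assay rather than at numbers, so the step between them cannot be read. The compounds shown leave open whether any group on that aromatic nitrogen would give a readable value in this assay.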